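Amino in place of hydrogen on a chloropurine core

This account rests on a few compounds, and the source may have more. Where it says the series, first, only, none or still open, it means among the compounds named here.

Of the compounds shown here, three that share one core have been measured so far. Compound 1 `ClCc1ccccc1Cn1cnc2c(Cl)nc(Cl)nc21` gives 6450 nM in a functional assay on 786-0 cells (Homo sapiens) for cytotoxicity, read by sulforhodamine B assay, with a stated time of 48 h; on this read-out higher numbers stand for lower toxicity in this test and lower numbers for higher toxicity in this test. Compound 2 `ClCc1ccccc1Cn1cnc2c(Cl)ncnc21` gives 83200 nM, and compound 3 `ClCc1cccc(Cn2cnc3ncnc(Cl)c32)c1` gives 70800 nM. Compound 2 stands with the highest number of the three; its nearest neighbour is compound 3, whose number lies within the scatter of it, while compound 1 lies well apart: the step of a 13-fold higher number from compound 1 to compound 2 (1.11 log units; beyond the scatter) is the one substantial difference seen.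

Compound 4 `Nc1nc(Cl)c2ncn(Cc3ccccc3CCl)c2n1` has not yet been measured. It differs from compound 2 by amino in place of hydrogen on an aromatic carbon, the new group sitting between two ring nitrogen atoms of the shared core. Among the measured compounds shown here, the only step on record, a 13-fold higher number from compound 1 to compound 2 (1.11 log units; beyond the scatter), concerns the same position but a different group, so it bears on the new change only loosely; no measured pair shows what an amino group does here. Compound 4 is therefore expected to stay close to compound 2, with a step of a 1.8-fold lower number from compound 2 to compound 4 (0.27 log units; within the scatter) that is not expected to exceed the scatter. The estimate for compound 4 is 45000 nM, with a range from 12000 nM to 160000 nM.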

Compound 4, concentration lethal to 50% of the cells: > 100000 nM
Compound 4: a limit, no number; the forecaster's own chance of this, stated with the estimate: 5%; middle value at least 2.2-fold (0.34 log units) from the limit.
By their numbers in this assay, from the lowest: compound 1; then compounds 3 and 2 (each within the scatter of the next). At a limit, above all of these: compound 4.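

In this assay compound 4 gives > 100000 nM, which is a limit of the assay and not a number. On an aromatic carbon between two ring nitrogen atoms, amino in place of hydrogen gives an at least 1.2-fold higher number from compound 2 to compound 4 (0.07 log units; that floor lies within the scatter), so compound 4 is not separated from compound 2 and the full size of this change stays unread: the limit of > 100000 nM in this assay, at which 1 of the 4 values shown sits. Amino in place of chloro at the same position gives an at least 15-fold higher number from compound 1 to compound 4 (1.19 log units; beyond the scatter), which shows that amino does not bring back the much lower number of compound 1, and among compound 1, compound 2 and compound 4 only the chloro compound keeps it.

On these data alone, it remains open whether bromo, methoxy or a methylamino group at this position would stay with compound 1 or with compound 2 and compound 4. Also open, as far as these compounds go, is whether amino at this position behaves the same way on the core of compound 3.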